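Swapping chlorine for fluorine on a halogenated phenyl ring

The source may hold more compounds than are shown below. What is called first, only, known or untested is meant among the compounds shown, and "the series" means these compounds.

Compound 2 `O=[N+]([O-])c1cc2c(O)c(-c3cc(Cl)cc(Cl)c3)c(O)nc2cc1Cl` carries a 3,5-dichlorophenyl group on the shared core. Among the compounds with values here, in an assay on isolated protein for inhibition of fatty acid synthase (Rattus norvegicus) (a lower number here means a stronger inhibitor, a higher number a weaker inhibitor), compound 2 gives 134 nM, the lowest of the two numbers measured so far. Within the data shown here, its only neighbour is compound 1 `O=[N+]([O-])c1cc2c(O)c(-c3ccc(F)cc3F)c(O)nc2cc1Cl`, which carries a 2,4-difluorophenyl group in the same position; in this assay compound 1 gives 173 nM, and the step of a 1.3-fold lower number from compound 1 to compound 2 (0.11 log units; within the scatter) is small enough to count as no real difference.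

Compound 3 `O=[N+]([O-])c1cc2c(O)c(-c3cc(F)cc(F)c3)c(O)nc2cc1Cl` has not yet been measured. It differs from compound 2 in one place: 3,5-difluorophenyl in place of 3,5-dichlorophenyl on an aromatic carbon. Among the measured compounds shown here, the one step that bears on this change, from a fluorinated to a chlorinated phenyl ring, is the step from compound 1 to compound 2, which stayed within the scatter. Going back from chlorine to fluorine, this time with the 3,5-difluorophenyl group in place of the 3,5-dichlorophenyl group, is therefore expected to move the number little, if at all, in this assay, with the estimated step from compound 2 to compound 3 being a 1.3-fold higher number from compound 2 to compound 3 (0.10 log units; within the scatter). Compound 3 is expected to give about 170 nM, within a range of 80 nM to 360 nM.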

Compound 3, half-maximal inhibitory concentration: 172 nM
For compound 3 the middle estimate is 1.0-fold (0.01 log units) below the measured one, and the stated range covers the measured number.
By their numbers in this assay, from the lowest: compounds 2, 3 and 1 (each within the scatter of the next).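

Replacing the 3,5-dichlorophenyl group with the 3,5-difluorophenyl group gives a 1.3-fold higher number from compound 2 to compound 3 (0.11 log units; within the scatter) in this assay and so compares chlorine with fluorine directly, with the halogens in the same ring positions. The earlier step changed the kind of halogen and its ring positions together, whereas replacing the 2,4-difluorophenyl group with the 3,5-difluorophenyl group gives a 1.0-fold lower number from compound 1 to compound 3 (0.00 log units; within the scatter) and isolates the positions of the two fluorines, so neither change taken alone produces a real difference among these compounds. No measurement here accounts for why these three halogenated phenyl groups read alike.

All three compounds carry a phenyl ring with two halogens at this position, so the result cannot say whether the halogens matter at all or whether the position would accept a quite different group. Going by these compounds, that question remains open for a plain phenyl ring, a phenyl ring bearing a methoxy group, an amine or a carboxylic acid, and a longer chain in place of the ring.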